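A few compounds are considered here, and "the series" means these few. Any claim that something is new, unique, unknown or untested is made for them only; others in the source may bear on it.

Compound 1, `CCN(CC)S(=O)(=O)c1ccc(S(=O)(=O)N2CCC[C@@H](C(=O)N(C)C(C)C)C2)cc1`, gives 7700 nM in a functional assay on BXPC-3 cells (Homo sapiens) for inhibition, read by MTT assay, with a stated time of 7 days; on this read-out higher numbers stand for weaker inhibition and lower numbers for stronger inhibition. Compound 2, `CCN(CC)C(=O)[C@@H]1CCCN(S(=O)(=O)c2ccc(S(=O)(=O)N(CC)CC)cc2)C1`, gives 10500 nM in this assay. Compound 3, `CCN1CC(NC(=O)[C@@H]2CCCN(S(=O)(=O)c3ccc(S(=O)(=O)N(CC)CC)cc3)C2)C1`, gives only a limit of the assay in this assay, > 30000 nM.

Compound 3 therefore stands at the weak end of the three values shown: its value is the limit (the limit of > 30000 nM in this assay, at which 1 of the 3 values shown sits), and its place relative to the other two is known only through an at least 3.8-fold higher number from compound 1 to compound 3 (0.59 log units; beyond the scatter) and an at least 2.8-fold higher number from compound 2 to compound 3 (0.45 log units; beyond the scatter), both beyond the scatter, whereas a 1.4-fold higher number from compound 1 to compound 2 (0.13 log units; within the scatter) lies within it.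

Compound 4, `CCN(CC)S(=O)(=O)c1ccc(S(=O)(=O)N2CCC[C@@H](c3nc(C)no3)C2)cc1`, differs from compound 3 in one place: 3-methyl-1,2,4-oxadiazol-5-yl in place of (1-ethylazetidin-3-yl)carbamoyl on a saturated ring carbon. Going by the values given here, no measured step follows this change. The two steps that reach compound 3 concern only the amine on the carbonyl carbon, and in compound 4 the carbonyl itself leaves together with the azetidine, so neither step measures the new group. What they do show is that compounds 1 and 2, which carry tertiary amides at this position, sit at numbers the assay can report, while compound 3 does not. Since the starting point is a limit, the size of the step to compound 4 cannot be fixed from a number; a return toward the range of compounds 1 and 2 is possible but not demonstrated. Compound 4 is therefore expected at about 15000 nM, between 5000 nM and 45000 nM, which would mean an expected step of an at least 2.0-fold lower number from compound 3 to compound 4 (0.30 log units; that floor lies within the scatter).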

Compound 4, half-maximal inhibitory concentration: 2900 nM
The estimate for compound 4 lay 5.2-fold (0.71 log units) above the measured number; measured number below the stated range.
By their numbers in this assay, from the lowest: compound 4; then compounds 1 and 2 (each within the scatter of the next). At a limit, above all of these: compound 3.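

The earlier compounds shown here varied only the amine on the carbonyl carbon, and compound 4 shows that in this assay this position on the saturated ring still gives a reportable number with no carbonyl there at all. The 3-methyl-1,2,4-oxadiazol-5-yl group improves on both tertiary amides, with a 3.6-fold lower number from compound 2 to compound 4 (0.56 log units; beyond the scatter) and a 2.7-fold lower number from compound 1 to compound 4 (0.42 log units; beyond the scatter) as its steps, although compounds 1 and 2 themselves lie within the scatter of each other. Against the (1-ethylazetidin-3-yl)carbamoyl group the step is larger, an at least 10-fold lower number from compound 3 to compound 4 (1.01 log units; beyond the scatter) and its true size stays open, since the value of compound 3 is a limit of the assay and not a number: the limit of > 30000 nM in this assay, at which 1 of the 4 values shown sits.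

On these data alone, whether the gain belongs to this particular ring or would also appear with a 3-ethyl-1,2,4-oxadiazol-5-yl group, a 1,3,4-oxadiazole or a carboxylic acid at the same place stays open. As far as these compounds go, all four compounds share the rest of the core, and whether the gain would hold with a morpholine in place of the diethylamino group is also open.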